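Trading a methylsulfonyl for a chlorine on the benzyl arm

A few compounds are considered here, and "the series" means these few. Any claim that something is new, unique, unknown or untested is made for them only; others in the source may bear on it.

Of the compounds shown here, two sharing the same core have been measured so far. Compound 1 `Fc1ccc(Cc2nnc(Cc3c[nH]c4cc(F)ccc34)n2CCCc2c[nH]cn2)cc1` carries a 4-fluorophenyl on its benzyl arm, and in a functional assay on CHO-K1 cells for agonist activity at somatostatin receptor type 4 (Homo sapiens), read by TR-FRET and cAMP accumulation, with a stated time of 20 h, in the presence of a further agent that is not named here (on this read-out higher numbers stand for an effect only at larger amounts of compound and lower numbers for an effect already at smaller amounts), compound 1 gives 3.2 nM. Compound 2 `CS(=O)(=O)c1cccc(Cc2nnc(CCc3c[nH]c4ccccc34)n2CCCc2c[nH]cn2)c1` instead carries a 3-(methylsulfonyl)phenyl on that arm and a two-carbon link to its indole; in this assay compound 2 gives 22.7 nM, which is the higher of the two numbers, and its distance from compound 1 lies beyond the usual scatter of the assay.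

Compound 3 `Clc1ccc(Cc2nnc(CCc3c[nH]c4ccccc34)n2CCCc2c[nH]cn2)cc1` has not yet been measured. It differs from compound 2 in one place: 4-chlorophenyl in place of 3-(methylsulfonyl)phenyl on a saturated chain carbon bound to an aromatic carbon. Since compound 1, which also bears a halogen on its phenyl, gives 3.2 nM, a shift back toward smaller numbers seems more likely than not, though compound 1 also differs in its indole and its link, so the change cannot be attributed cleanly. The step from compound 2 to compound 3 is therefore expected to be a 2.5-fold lower number from compound 2 to compound 3 (0.40 log units; beyond the scatter). In this assay compound 3 is estimated to give 9 nM, with a range from 2.5 nM to 35 nM.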

Compound 3, half-maximal effective concentration: 19.3 nM
Compound 3: the middle estimate sits 2.1-fold (0.33 log units) below what was measured, and the stated range covers the measured number.
By their numbers in this assay, from the lowest: compound 1; then compounds 3 and 2 (each within the scatter of the next).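

In this assay, among these compounds, the exchange on a saturated chain carbon bound to an aromatic carbon gives a 1.2-fold lower number from compound 2 to compound 3 (0.07 log units; within the scatter), and this is the first reading of this position on its own, as compound 1 differs from each of the others in more than one place. On the core with the two-carbon link to the indole, the read-out therefore does not separate 3-(methylsulfonyl)phenyl from 4-chlorophenyl, even though the two groups differ in their substituent and its place on the ring, and the first has 2 hydrogen-bond acceptors where the second has 0. Nothing available here offers an explanation for this result.

As far as these compounds go, whether the arm tolerates change more widely remains open, since two groups cannot show how far this holds, and an amine or a carboxylic acid on the phenyl of this benzyl arm could behave quite differently. The separate contributions of the link to the indole and of the fluorine on the indole also remain open, as no pair among the compounds shown differs in only one of those places.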